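The compounds below may be only part of what the source reports. "The series", "measured", "known", "first", "only" and "open" are said of these compounds alone.

Working notes on a hydroxamic acid series and its trifluoromethyl ketone counterparts, assessed in a functional assay on NCI-H661 cells (Homo sapiens) for antiproliferative activity, read by MTT assay, with a stated time of 72 h; on this read-out higher numbers stand for weaker inhibition and lower numbers for stronger inhibition.

Compound 1 `O=C(CCCCCCc1nc(-c2ccc(C(F)(F)F)cc2)no1)NO` gives 15300 nM in this assay. Compound 2 `O=C(CCCCCCc1nc(-c2ccc(F)cc2)no1)NO` gives 19400 nM. The two are related by fluoro in place of trifluoromethyl on an aromatic carbon and the step between them is a 1.3-fold higher number from compound 1 to compound 2 (0.10 log units; within the scatter), so the two values are read as equivalent within measurement noise.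

Compound 3 `O=C(CCCCCCc1nc(-c2ccc(C(F)(F)F)cc2)no1)C(F)(F)F` gives 6390 nM, the lowest of the three numbers. Among the measured compounds shown here, compound 3 differs from compound 1 by trifluoromethyl in place of hydroxyamino on a carbonyl carbon, and the step is a 2.4-fold lower number from compound 1 to compound 3 (0.38 log units; beyond the scatter); this is the only change among the measured compounds that moves the read-out beyond the scatter.

Compound 4 `O=C(CCCCCCc1nc(-c2ccc(F)cc2)no1)C(F)(F)F` is not yet measured in this assay. It stands to compound 3 as compound 2 stands to compound 1: the change is fluoro in place of trifluoromethyl on an aromatic carbon, and the two cores differ by the change described for compound 1 to compound 3. The same change, made once before on the hydroxamic acid core, produced a 1.3-fold higher number from compound 1 to compound 2 (0.10 log units; within the scatter), a step that does not leave the scatter.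

For the measured compounds named here, with only that one precedent, the expected step from compound 3 to compound 4 is a 1.3-fold higher number from compound 3 to compound 4 (0.10 log units; within the scatter), mirroring the step from compound 1 to compound 2 because a 1.3-fold higher number from compound 1 to compound 2 (0.10 log units; within the scatter) was within the scatter. Compound 4 is therefore estimated at 8000 nM, with a range of 4500 nM to 15000 nM to cover the possibility that the change reads differently on the trifluoromethyl ketone core.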

Compound 4, half-maximal inhibitory concentration: 12700 nM
Estimate against measurement, compound 4: 1.6-fold (0.20 log units) below; the measured number falls inside the stated range.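

Fluoro in place of trifluoromethyl on the aromatic carbon gives, on the core of compound 3 in this assay, a 2.0-fold higher number from compound 3 to compound 4 (0.30 log units; within the scatter), and this step cannot be told apart from the one on the core of compound 1: the same change on two cores in this assay, a 1.3-fold higher number (0.10 log units; within the scatter) from compound 1 to compound 2 and a 2.0-fold higher number (0.30 log units; within the scatter) from compound 3 to compound 4, 1.6-fold (0.20 log units) apart, within the scatter of two such steps

Trifluoromethyl in place of hydroxyamino on the carbonyl carbon, read on the fluoro pair, gives a 1.5-fold lower number from compound 2 to compound 4 (0.18 log units; within the scatter), so the one step beyond the scatter in the series does not repeat as such on the second pair, though the two steps still cannot be told apart: the same change on two cores in this assay, a 2.4-fold lower number (0.38 log units; beyond the scatter) from compound 1 to compound 3 and a 1.5-fold lower number (0.18 log units; within the scatter) from compound 2 to compound 4, 1.6-fold (0.20 log units) apart, within the scatter of two such steps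

This shows that each change reads alike on the two cores at the resolution of this assay, but it does not show that either step has the same true size on both, and with only these four compounds it establishes no rule for other cores.

Open, going by these compounds, is how other groups on that aromatic carbon, such as a nitrile or an amine, would read on either core. Also open, on these data alone, are a carboxylic acid in place of hydroxyamino on the carbonyl carbon and a longer chain, and whether either would keep the two changes reading alike.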